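Sulfone series: hydroxy added to the methoxyphenyl of compound 3

A few compounds are considered here, and "the series" means these few. Any claim that something is new, unique, unknown or untested is made for them only; others in the source may bear on it.

Within the data shown here, compound 3 `COc1ccc(/C=C(\C(=O)c2ccc(Cl)cc2)S(=O)(=O)c2ccc(Br)cc2)cc1` gives 10000 nM in a functional assay on DU-145 cells (Homo sapiens) for inhibition, read by trypan blue exclusion, with a stated time of 96 h (on this read-out higher numbers stand for weaker inhibition of growth and lower numbers for stronger inhibition of growth), the second highest of the three numbers measured so far. Nearest stands compound 2 `O=C(/C(=C\c1ccccc1F)S(=O)(=O)c1ccc(Br)cc1)c1ccc(Cl)cc1`, which gives 25000 nM; the step of a 2.5-fold lower number from compound 2 to compound 3 (0.40 log units; beyond the scatter) is the only measured change on that aromatic ring. Furthest stands compound 1 `COc1ccc(/C=C(/Sc2ccc(C)cc2)C(=O)c2ccc(Cl)cc2)cc1O`, which gives 1000 nM in this assay. Compound 4 `COc1ccc(/C=C(\C(=O)c2ccc(Cl)cc2)S(=O)(=O)c2ccc(Br)cc2)cc1O` differs from compound 3 by hydroxy in place of hydrogen on an aromatic carbon. Among the measured compounds shown here, no measured step covers exactly this change. For the measured compounds named here, the single ring change measured, a 2.5-fold lower number from compound 2 to compound 3 (0.40 log units; beyond the scatter), was modest, and compound 1, which carries the same hydroxy, shows the lowest number at 1000 nM. A modest decrease is therefore expected: a 2.0-fold lower number from compound 3 to compound 4 (0.30 log units; within the scatter). Compound 4 is estimated at 5000 nM, with a range from 1500 nM to 15000 nM.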

Compound 4, concentration for 50% growth inhibition: 10000 nM
Compound 4: the middle estimate sits 2.0-fold (0.30 log units) below what was measured; low and high end bracket the measured number.
By their numbers in this assay, from the lowest: compound 1; then compounds 3 and 4 (each within the scatter of the next); then compound 2.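

In the sulfone series, putting hydroxy on the aromatic carbon ortho to the methoxy group gives no change at the digits printed from compound 3 to compound 4 (within the scatter) in this assay, so this position tolerates the added group without a readable shift. The ring exchange still reads a 2.5-fold lower number from compound 2 to compound 4 (0.40 log units; beyond the scatter), while the exchange at the sulfur substituent, with 3-hydroxy-4-methoxyphenyl kept, reads a 10-fold higher number from compound 1 to compound 4 (1.00 log units; beyond the scatter), so this ring alone does not carry the low number of compound 1. No supporting data bear on this result.

Going by these compounds, whether an amine or a longer alkoxy chain at this position would move the number remains open. So does whether the hydroxy matters in compounds carrying (4-methylphenyl)sulfanyl.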